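This account rests on a few compounds, and the source may have more. Where it says the series, first, only, none or still open, it means among the compounds named here.

Measured so far:
- compound 1 `COc1ccc2cc(C(C)c3nnc4n3N=C(c3ccc(OC(F)(F)F)cc3)CS4)ccc2c1` gives 8800 nM in a functional assay on MCF7 cells (Homo sapiens) for inhibition, read by sulforhodamine B assay, with a stated time of 72 h; on this read-out higher numbers stand for weaker inhibition and lower numbers for stronger inhibition
- compound 2 `CC(C)Cc1ccc(C(C)c2nnc3n2N=C(c2ccc(Cl)cc2)CS3)cc1` gives 8800 nM in this assay
- compound 3 `CC(C)Cc1ccc(C(C)c2n[nH]c(=S)n2N)cc1` gives 16100 nM in this assay

Compound 1 and compound 2 give the same number at the digits reported, and the number for compound 3 lies within the usual scatter of both, so the three measurements cannot be told apart on this read-out. Compound 1 therefore stands nowhere in particular: neither above nor below its neighbours in any way the scatter would allow one to claim.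

Compound 4 `COc1ccc2cc(C(C)c3nnc4n3N=C(c3ccc(Cl)cc3Cl)CS4)ccc2c1` has not yet been measured in this assay. It differs from compound 1 in one place: 2,4-dichlorophenyl in place of 4-(trifluoromethoxy)phenyl on a carbon with a double bond to nitrogen. Going by the values given here, no measured pair shows what this exchange does on its own. Among the compounds with values here, compound 2 differs from compound 1 in more than one place, so it gives no clean step for this exchange, and compound 3 lacks the fused system altogether. With nothing in the data pointing either way, the expectation is that the number stays close to that of compound 1. In this assay the expected step is a 1.0-fold higher number from compound 1 to compound 4 (0.01 log units; within the scatter), no larger than the scatter. The number for compound 4 is estimated at 9000 nM, with a range from 4000 nM to 20000 nM.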

Compound 4, half-maximal inhibitory concentration: 14600 nM
For compound 4 the middle estimate is 1.6-fold (0.21 log units) below the measured one, and the stated range covers the measured number.
By their numbers in this assay, from the lowest: compounds 1, 2, 4 and 3 (each within the scatter of the next).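

In this assay, putting 2,4-dichlorophenyl in place of 4-(trifluoromethoxy)phenyl on the carbon with a double bond to nitrogen gives a 1.7-fold higher number from compound 1 to compound 4 (0.22 log units; within the scatter), so the two compounds cannot be told apart on this read-out. Going by these compounds alone, this is the first pair in the set that differs in one place only, and it shows that two quite different substituted phenyl groups, one carrying oxygen and fluorine and the other carrying two chlorine atoms, read alike at this position, although this single pair cannot establish a general rule. Nothing available explains this outcome or links it to any property of either group.

On these data alone, what happens with a group of another kind at this position remains open, for example a phenyl ring carrying an amine or a carboxylic acid, or a plain phenyl ring with no substituent at all. Within the data shown here, it is also open whether the same exchange would read the same way if the rest of the molecule were different, since only one pair speaks to it.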